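The compounds below may be only part of what the source reports. "The series", "measured", "known", "first", "only" and "open" are said of these compounds alone.

Measured so far:
- Compound 1, `O=C(O)c1ccccc1-c1ccc(CCc2ncc(Cc3cccc(Cl)c3)[nH]2)cc1`, gives 825 nM in an in vitro functional assay on cells for agonist activity at Bombesin receptor subtype-3 (Homo sapiens), read by luminescence and calcium flux; a lower number here means that less compound is needed, a higher number that more compound is needed for the effect.
- Compound 2, `COc1ccccc1Cc1cnc(CCc2ccc(-c3ccccc3C(=O)O)cc2)[nH]1`, gives 1720 nM in this assay.

Among the compounds with values here, compound 2 stands at the higher of the two numbers seen so far; its nearest neighbour is compound 1, and the one step between them, a 2.1-fold higher number from compound 1 to compound 2 (0.32 log units; beyond the scatter), is modest yet beyond the usual scatter. The two compounds share a core and differ only in the ring that hangs from a saturated chain carbon bound to an aromatic carbon.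

Compound 3, `Cc1ccc(Cc2cnc(CCc3ccc(-c4ccccc4C(=O)O)cc3)[nH]2)cc1`, has not yet been measured. It differs from compound 2 at exactly that same place: 4-methylphenyl in place of 2-methoxyphenyl on a saturated chain carbon bound to an aromatic carbon.

Within the data shown here, the only measured step that bears on this change is the one from compound 1 to compound 2, which swapped one ring for another at the same place and moved the number by a modest amount. Among the measured compounds shown here, no measured pair shows 4-methylphenyl itself, so the direction is open. A step of similar size in this assay, in either direction, is the most that can be expected; compound 3 is estimated at 1300 nM, within 500 nM to 3500 nM, meaning an expected step of a 1.3-fold lower number from compound 2 to compound 3 (0.12 log units; within the scatter).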

Compound 3, half-maximal effective concentration: 2660 nM
Beside the measured number, compound 3's estimate is 2.0-fold (0.31 log units) below it, within the range that was stated.
By their numbers in this assay, from the lowest: compound 1; then compounds 2 and 3 (each within the scatter of the next).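

The new compound shows that this position tolerates a second kind of change without a clear shift: 4-methylphenyl in place of 2-methoxyphenyl gives a 1.5-fold higher number from compound 2 to compound 3 (0.19 log units; within the scatter), so the two compounds cannot be told apart here, even though the methoxy oxygen is gone and the substituent on the ring has changed. Compound 1 now stands apart from both other compounds, since replacing its 3-chlorophenyl with 4-methylphenyl gives a 3.2-fold higher number from compound 1 to compound 3 (0.51 log units; beyond the scatter), a larger step than the earlier one and beyond the scatter, which makes 3-chlorophenyl the best of the three rings shown at this place. No supporting measurement is available to explain why the 3-chlorophenyl compound needs less compound for the effect.

With a single chlorine-bearing ring among the three, these compounds cannot show whether chlorine itself matters or whether any ring carrying a group at that spot would do as well. Also open, going by these compounds, is how the number would respond to a quite different group on this ring, such as an amine or a carboxylic acid, or to a longer chain linking the ring to the shared core.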